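Benzyl in place of oxan-4-yl on the pyrazole nitrogen

This account rests on a few compounds, and the source may have more. Where it says the series, first, only, none or still open, it means among the compounds named here.

Measured compounds:
compound 1 `Cc1cc(NC(=O)Cn2nnc(-c3ccccc3)n2)n(C2CCOCC2)n1` gives 115%
compound 2 `CC1CC1c1cc(NC(=O)Cn2nnc(-c3ccccc3)n2)n(C2CCCCC2)n1` gives 78%

In an assay on HEK293 cells for activation of Kir3.1/Kir3.2 (Homo sapiens), read by thallium flux (a higher number here means a larger maximal response, a lower number a smaller maximal response), compound 1 stands highest of the two numbers measured, and compound 2 lies lower by an amount beyond the usual scatter; the two compounds differ in more than one place, so the values are simply compared. Compound 3 `Cc1cc(NC(=O)Cn2nnc(-c3ccccc3)n2)n(Cc2ccccc2)n1` is not yet measured. It differs from compound 1 by benzyl in place of oxan-4-yl on an aromatic nitrogen. Going by the values given here, no single-change step has been measured, so the size of the change is expected to be small, downward, near the edge of the scatter: a number 17 percentage points lower from compound 1 to compound 3 (beyond the scatter). Compound 3 is therefore expected to reach 98%, within 62% to 128%.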

Compound 3, largest response reached (Emax), in percent of the reference or control that the assay uses: 74%
Compound 3: the middle estimate sits 24 percentage points above what was measured, within the range that was stated.
By their numbers in this assay, from the lowest: compounds 3 and 2 (each within the scatter of the next); then compound 1.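

In this assay, benzyl in place of oxan-4-yl on the aromatic nitrogen gives a number 41 percentage points lower from compound 1 to compound 3 (beyond the scatter), a large step. Going by these compounds alone, this is the only single-place comparison here, and it shows that the maximal response depends clearly on the group at this position, which the two earlier compounds, differing in more than one place, could not show. Nothing available explains the step. Going by these compounds, it remains open whether the ring oxygen of oxan-4-yl matters, which piperidin-4-yl, carrying an amine in its place, or cyclohexyl on the core of compound 1 could address.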